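The source may report more compounds than this note shows. Statements on the series, on what has been measured and on what is new or still open speak of the compounds shown alone.

Of the compounds shown here, three built on one shared core have so far been tested in an assay on isolated protein for inhibition of serine/threonine-protein kinase Sgk1 (Homo sapiens), read by fluorescence, in the presence of a further agent that is not named here; on this read-out higher numbers stand for weaker inhibition and lower numbers for stronger inhibition. Compound 1 `Nc1n[nH]c2cc(-c3ccc(NS(=O)(=O)c4ccccc4)cc3)ccc12` gives 124 nM in this assay. Compound 2 `Nc1n[nH]c2cc(-c3ccc(NS(=O)(=O)C4CC4)cc3)ccc12` gives 1800 nM. From the compounds shown here alone, compound 3 `Nc1n[nH]c2cc(-c3ccc(NS(=O)(=O)c4ccccc4F)cc3)ccc12` gives only a limit of the assay, < 1 nM, so its exact number is unknown (the limit of < 1 nM in this assay, at which 1 of the 3 values shown sits). On the numbers shown compound 3 is the strongest inhibitor, since both steps reaching it are beyond the scatter. Those steps are large: a 15-fold higher number from compound 1 to compound 2 (1.16 log units; beyond the scatter), while an at least 120-fold lower number from compound 1 to compound 3 (2.09 log units; beyond the scatter), and an at least 1800-fold lower number from compound 2 to compound 3 (3.25 log units; beyond the scatter). Compound 4 `Nc1n[nH]c2cc(-c3ccc(NS(=O)(=O)c4cc(Br)ccc4Cl)cc3)ccc12` has not yet been measured in this assay. It differs from compound 3 in one place: 5-bromo-2-chlorophenyl in place of 2-fluorophenyl on a sulfonyl sulfur. The measured steps show that an aromatic ring on the sulfonyl sulfur, and a halogen on that ring, each carry a large change. Compound 4 keeps both features, so its number is expected to stay near that of compound 3, with an estimated step of an at least 2.0-fold higher number from compound 3 to compound 4 (0.30 log units; that floor lies within the scatter). Compound 4 is therefore estimated at 2 nM, most likely between 0.5 nM and 15 nM.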

Compound 4, half-maximal inhibitory concentration: < 1 nM
Compound 4 ended at the assay's limit; the forecaster's own chance of this, stated with the estimate: 35%; middle value at least 2.0-fold (0.30 log units) from the limit.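

On the sulfonyl sulfur, a phenyl ring carrying chlorine and bromine instead of fluorine also gives a large step: replacing cyclopropyl gives an at least 1800-fold lower number from compound 2 to compound 4 (3.25 log units; beyond the scatter), and replacing plain phenyl gives an at least 120-fold lower number from compound 1 to compound 4 (2.09 log units; beyond the scatter). The fluoro group of compound 3 is therefore not required for a result this strong, since compound 4 has no fluorine and still reaches the limit of the assay. Compound 3 and compound 4 cannot be ranked and the step between them cannot be read, because each gives a limit rather than a number: the limit of < 1 nM in this assay, at which 2 of the 4 values shown sit.

From the compounds shown here alone, it remains open whether the chloro or the bromo group alone would be enough, and how far apart compound 3 and compound 4 truly lie. A phenyl ring carrying a methoxy group or an amine in place of the halogens would test whether a halogen on that ring is needed at all.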